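Solubility of a spiro urea: tert-butyl to 2-chlorophenyl

This account rests on a few compounds, and the source may have more. Where it says the series, first, only, none or still open, it means among the compounds named here.

Measured so far:
compound 1, `CC(C)(C)C(=O)N1CCC2(CC1)CN(C(=O)Nc1ccc(C(F)(F)F)cc1)CCO2`: 73 ug/mL
compound 2, `O=C(Nc1ccc(C(F)(F)F)cc1)N1CCOC2(CCN(C(=O)c3c(F)cccc3F)CC2)C1`: 38 ug/mL

In an ADME assay for solubility, in simulated intestinal fluid (a lower number here means a less soluble compound, a higher number a more soluble compound), compound 1 gives 73 ug/mL and compound 2 gives 38 ug/mL; the two values sit within the scatter of each other, so compound 1 is not set apart on the numbers shown. Within the data shown here, the one measured step, a 1.9-fold lower number from compound 1 to compound 2 (0.28 log units; within the scatter), is the only comparison that bears on the unmeasured compound 3, `O=C(Nc1ccc(C(F)(F)F)cc1)N1CCOC2(CCN(C(=O)c3ccccc3Cl)CC2)C1`. Compound 3 differs from compound 1 by 2-chlorophenyl in place of tert-butyl on a carbonyl carbon. That change is of the same kind as the step to compound 2, an aryl group on the carbonyl carbon in place of tert-butyl, so a step of similar size and the same direction is expected, a 2.1-fold lower number from compound 1 to compound 3 (0.32 log units; beyond the scatter), though it may well stay within the scatter. Compound 3 is therefore expected to give 35 ug/mL in this assay, with a range from 15 ug/mL to 80 ug/mL.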

Compound 3, solubility: 12 ug/mL
Beside the measured number, compound 3's estimate is 2.9-fold (0.46 log units) above it; the whole stated range lies above it.
By their numbers in this assay, from the lowest: compound 3; then compounds 2 and 1 (each within the scatter of the next).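

A step of a 6.1-fold lower number from compound 1 to compound 3 (0.78 log units; beyond the scatter) in this assay shows what the earlier pair could not: a change on this carbonyl carbon can carry the number beyond the scatter. The two aryl groups do not read alike either, with a 3.2-fold lower number from compound 2 to compound 3 (0.50 log units; beyond the scatter) separating 2-chlorophenyl from 2,6-difluorophenyl at the same place. Nothing shown here accounts for either step.

The compounds shown leave open whether the lower number goes with the chlorine or with the aromatic ring itself, a question that plain phenyl or 2-fluorophenyl on the same carbonyl carbon would address. They also leave open how a pyridyl group, or a chain ending in an amine, would read at this place.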